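Phenyl for pyrimidinyl on the sulfonamide nitrogen

The compounds below may be only part of what the source reports. "The series", "measured", "known", "first", "only" and "open" are said of these compounds alone.

The series rests on a shared core in which a benzamide is linked to an aryl sulfonamide. Compound 1 `N#Cc1ccc(C(=O)Nc2ccc(S(=O)(=O)Nc3ccccc3)cc2)c(F)c1` is the reference point: in a functional assay on HEK293 cells for agonist activity at probable G-protein coupled receptor 27 (Homo sapiens), read by a luciferase reporter and beta-arrestin recruitment, with a stated time of 10 min (on this read-out lower numbers stand for an effect already at smaller amounts and higher numbers for an effect only at larger amounts of compound), compound 1 gives 229 nM. Compound 2 `O=C(Nc1ccc(S(=O)(=O)Nc2ncccn2)cc1)c1ccc(Cl)cc1Cl` carries a pyrimidin-2-yl on the sulfonamide nitrogen and a dichlorinated benzamide. In this assay compound 2 reaches only a limit of the assay, > 100000 nM, so its position on the numbers is known only as the limit of > 100000 nM in this assay, at which 1 of the 2 values shown sits. Compound 3 `O=C(Nc1ccc(S(=O)(=O)Nc2ccccc2)cc1)c1ccc(Cl)cc1Cl` has not been measured. It differs from compound 2 by phenyl in place of pyrimidin-2-yl on a sulfonamide nitrogen. Within the data shown here, no measured step covers this change, but compound 1, which also carries a phenyl on the sulfonamide nitrogen, gives 229 nM, so a large step from compound 2 to compound 3 toward lower numbers is expected, estimated as an at least 50-fold lower number from compound 2 to compound 3 (1.69 log units; beyond the scatter). Compound 3 is accordingly expected to give 2000 nM, with a range from 300 nM to 30000 nM.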

Compound 3, half-maximal effective concentration: 457 nM
Compound 3: the middle estimate sits 4.4-fold (0.64 log units) above what was measured; measured number inside the range.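

Among these compounds, with the 2,4-dichlorophenyl on the carbonyl carbon held fixed, phenyl in place of pyrimidin-2-yl on the sulfonamide nitrogen gives an at least 210-fold lower number from compound 2 to compound 3 (2.34 log units; beyond the scatter), which is the first direct reading of this change in this assay. Compound 2 stands at a limit of the assay, so the size of that step is a bound and not an exact figure: the limit of > 100000 nM in this assay, at which 1 of the 3 values shown sits. With phenyl kept on the sulfonamide nitrogen, 2,4-dichlorophenyl in place of 4-cyano-2-fluorophenyl on the carbonyl carbon gives a 2.0-fold higher number from compound 1 to compound 3 (0.30 log units; within the scatter), so this pair shows that the two groups on the carbonyl carbon are not told apart beyond the scatter.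

The compounds shown leave open how far the sulfonamide nitrogen tolerates other groups, such as a pyridin-2-yl, a cyclohexyl or a methyl. They also leave open whether a methoxy or a chlorine on the phenyl itself would shift the number.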